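One more carbon on the chain and metabolic half-life

The source may hold more compounds than are shown below. What is called first, only, known or untested is meant among the compounds shown, and "the series" means these compounds.

Compound 1 `CCCCCNC(=O)Oc1ccc(Cl)cc1C(=O)Nc1ccc(Cl)cc1` and compound 2 `CCCCCCNC(=O)Oc1ccc(Cl)cc1C(=O)Nc1ccc(Cl)cc1` share a core and differ only in the length of a saturated chain. In an ADME assay for metabolic stability, read by HPLC, at pH 7 (a higher number here means that the compound lasts longer, a lower number that the compound disappears faster), compound 1 gives 64 h, and compound 2 gives 64 h. The change between them, (methyl in place of hydrogen on a saturated chain carbon, five bonds along the chain from an amide-type nitrogen), produced a step of no change at the digits printed from compound 1 to compound 2 (within the scatter).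

Compound 3 `CCCCCCCCCNC(=O)Oc1ccc(Cl)cc1C(=O)Nc1ccc(Cl)c(Cl)c1` carries a longer chain and a different core; the difference between the two cores is not broken down here. In this assay compound 3 gives 64 h, level with compound 1 and compound 2 within the scatter.

Compound 4 `CCCCCCCCCCNC(=O)Oc1ccc(Cl)cc1C(=O)Nc1ccc(Cl)c(Cl)c1` differs from compound 3 by methyl in place of hydrogen on a saturated chain carbon, nine bonds along the chain from an amide-type nitrogen. Among the compounds with values here, this is the same kind of change as the one between compound 1 and compound 2, but the place differs: there the methyl entered five bonds along the chain from an amide-type nitrogen, here nine bonds along the chain from an amide-type nitrogen. Given no change at the digits printed from compound 1 to compound 2 (within the scatter), the step is expected to be no change at the digits printed from compound 3 to compound 4 (within the scatter). Compound 4 is therefore estimated at 64 h, with a range from 32 h to 128 h.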

Compound 4, half-life: 64 h
Beside the measured number, compound 4's estimate shows no gap at the digits printed; low and high end bracket the measured number.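

Replacing a hydrogen with a methyl at the end of the chain gave a step of no change at the digits printed from compound 3 to compound 4 (within the scatter) in this assay, and set beside the earlier step on the core of compound 1, the change carried over from one core to the other: the same change on two cores in this assay, no change at the digits printed (within the scatter) from compound 1 to compound 2 and no change at the digits printed (within the scatter) from compound 3 to compound 4, 1.0-fold (0.00 log units) apart, within the scatter of two such steps. In both pairs, then, one more carbon left the half-life where it stood, whether the methyl entered five bonds or nine bonds along the chain from an amide-type nitrogen. Within the data shown here, this rests on only two pairs, however, which differ in both core and chain length, so it does not separate the two differences or establish a rule for other cores or chain lengths.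

The compounds shown leave open whether a much shorter chain, such as propyl, would read the same in this assay. They also leave open what a branched chain, a chain ending in an amine or a carboxylic acid, or a ring in place of the chain would do.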